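The source may report more compounds than this note shows. Statements on the series, on what has been measured and on what is new or still open speak of the compounds shown alone.

In a physicochemical assay for solubility, in phosphate buffer, at pH 7.4 (on this read-out higher numbers stand for higher solubility and lower numbers for lower solubility), compound 3 `CC(=O)N[C@@H]1CCC[C@H](C(=O)Nc2cc(-c3nnn4ccccc34)c(Cl)cn2)C1` gives 530000 nM. Compound 1 `CC(=O)N[C@@H]1CCC[C@H](C(=O)Nc2cc(-c3cnn4c3CCCC4)c(Cl)cn2)C1` gives 310000 nM, and a 1.7-fold higher number from compound 1 to compound 3 (0.23 log units; within the scatter) does not separate the two. Compound 2 `CC(=O)N[C@@H]1CCC[C@H](C(=O)Nc2cc(-c3cnc4ccccn34)c(Cl)cn2)C1` gives 120000 nM, and compound 3 stands clearly apart from it, with a 4.4-fold higher number from compound 2 to compound 3 (0.65 log units; beyond the scatter).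

Compound 4 `CC(=O)N[C@@H]1CCC[C@H](C(=O)Nc2cc(-c3cnn4c3CCC4)c(Cl)cn2)C1` differs from compound 3 in one place: a group of 8 heavy atoms (6 carbon, 2 nitrogen; one five-membered non-aromatic ring with 1 hetero atom, one five-membered aromatic ring with 2 hetero atoms) in place of a group of 9 heavy atoms (6 carbon, 3 nitrogen; one five-membered aromatic ring with 3 hetero atoms, one six-membered aromatic ring with 1 hetero atom), on an aromatic carbon. Within the data shown here, the entering group carries a non-aromatic ring, and compound 1 is the only measured compound that also has one, though six-membered. Two measured steps therefore bear on this change, and both replace that non-aromatic ring with an aromatic one. They are a 2.6-fold lower number from compound 1 to compound 2 (0.41 log units; beyond the scatter) and the smaller 1.7-fold higher number from compound 1 to compound 3 (0.23 log units; within the scatter). Together they point to no firm direction, but compound 1 is the nearest guide, with its value of 310000 nM. A small drop, not beyond the scatter, is therefore expected, and the estimated step is a 1.5-fold lower number from compound 3 to compound 4 (0.18 log units; within the scatter). For compound 4 the estimated value is 350000 nM, with an expected range from 130000 nM to 800000 nM.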

Compound 4, solubility: 160000 nM
The estimate for compound 4 lay 2.2-fold (0.34 log units) above the measured number; measured number inside the range.
By their numbers in this assay, from the lowest: compounds 2, 4, 1 and 3 (each within the scatter of the next, the first and the last beyond it).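

In this assay, placing the group with one five-membered non-aromatic ring on this aromatic carbon gives a 3.3-fold lower number from compound 3 to compound 4 (0.52 log units; beyond the scatter). A non-aromatic ring in this place therefore need not match the group of compound 3, even though the six-membered non-aromatic ring of compound 1 could not be separated from that group. The new group cannot be separated from the other two, with a 1.3-fold higher number from compound 2 to compound 4 (0.12 log units; within the scatter) and a 1.9-fold lower number from compound 1 to compound 4 (0.29 log units; within the scatter), so compound 3 now stands apart from compound 2 and compound 4, but not from compound 1.

Nothing measured here says why these groups differ. Every group shown in this place has two rings, so it remains open how an amine or a carboxylic acid on the same aromatic carbon would read.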